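The source may hold more compounds than are shown below. What is called first, only, known or untested is meant among the compounds shown, and "the series" means these compounds.

Of the compounds shown here, two have been measured so far in a physicochemical assay for lipophilicity; on this read-out higher numbers stand for higher lipophilicity and lower numbers for lower lipophilicity. Compound 2 `C=C(c1ccc2ccccc2c1)C1CCC2(CC1)COC(Nc1ccccc1)OO2` gives 5.59, and compound 1 `C=C(c1cccc2ccccc12)C1CCC2(CC1)COC(Nc1ccc(F)cc1)OO2` gives 5.75. For the measured compounds named here, these two values lie within the scatter of each other, so compound 2 stands level with the only other number available. The next compound, compound 3 `C=C(c1ccc2ccccc2c1)C1CCC2(CC1)COC(Nc1ccc(F)cc1)OO2`, is made from compound 2 by a single change, fluoro in place of hydrogen on an aromatic carbon, turning the anilino group into a (4-fluorophenyl)amino group. The two measured compounds differ in more than one place, so the data hold no direct measurement of this change alone. Compound 1 does carry the same (4-fluorophenyl)amino group and gives 5.75, which offers a rough guide to where compound 3 may fall. A small upward shift is therefore expected, one that may not clear the scatter. The estimated change is a number 0.16 log units higher from compound 2 to compound 3 (within the scatter). Compound 3 is expected to read 5.75, with an estimated range from 5.45 to 6.05.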

Compound 3, partition coefficient: 5.75
Beside the measured number, compound 3's estimate shows no gap at the digits printed; the range from low to high includes it.
By their numbers in this assay, from the lowest: compounds 2, 1 and 3 (each within the scatter of the next).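

In this assay, for the compounds shown here, the first direct reading of this position is the step of fluoro in place of hydrogen on an aromatic carbon, para to a large group: a number 0.16 log units higher from compound 2 to compound 3 (within the scatter). That step turns anilino into (4-fluorophenyl)amino and leaves the two compounds level, which the earlier pair could not show, as they differ in more than one place. With the (4-fluorophenyl)amino group held constant, naphthalen-2-yl in place of naphthalen-1-yl also gives a direct comparison, with no change at the digits printed from compound 1 to compound 3 (within the scatter), so neither single change separates its pair on this read-out. Nothing measured here bears on what lies behind these two steps.

Whether a chloro, methoxy, trifluoromethyl or amine group at this same place would stay level with hydrogen remains open, since fluoro is the only replacement shown. Also open is whether the fluoro step would read the same with naphthalen-1-yl on the chain, as no compound among those shown pairs that group with a plain anilino group.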